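A few compounds are considered here, and "the series" means these few. Any claim that something is new, unique, unknown or untested is made for them only; others in the source may bear on it.

Measured in a functional assay on V79-379A cells (Cricetulus griseus) for cytotoxicity, read by MTT assay, in the presence of a further agent that is not named here; on this read-out higher numbers stand for weaker inhibition and lower numbers for stronger inhibition:
- compound 1 `COC1=CC(=O)c2c(c(COC(=O)c3ccccc3F)c(C)n2C)C1=O`: 164000 nM
- compound 2 `COC1=CC(=O)c2c(c(COC(C)=O)c(C)n2C)C1=O`: 27000 nM

Going by the values given here, compound 2 has the lowest number so far, and the only measured step is a 6.1-fold lower number from compound 1 to compound 2 (0.78 log units; beyond the scatter). That step is a modest one, and it changed the group on a carbonyl carbon. Compound 3 `COC1=CC(=O)c2c(c(Cc3cc(F)ccc3O)c(C)n2C)C1=O` goes further, with 5-fluoro-2-hydroxyphenyl in place of acetoxy on a saturated chain carbon bound to an aromatic carbon. The ester is gone, so the measured step is only a rough guide. In this assay, a similarly modest rise is expected, since compound 1, which also carries a fluorinated aromatic ring, stands at 164000 nM. The expected change is a 2.2-fold higher number from compound 2 to compound 3 (0.35 log units; beyond the scatter). For compound 3 the estimate is 60000 nM, with a range of 12000 nM to 250000 nM.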

Compound 3, half-maximal inhibitory concentration: 200000 nM
Estimate against measurement, compound 3: 3.3-fold (0.52 log units) below, within the range that was stated.
By their numbers in this assay, from the lowest: compound 2; then compounds 1 and 3 (each within the scatter of the next).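

Replacing acetoxy with 5-fluoro-2-hydroxyphenyl on the saturated chain carbon removes the ester altogether and gives a 7.4-fold higher number from compound 2 to compound 3 (0.87 log units; beyond the scatter) in this assay. Among these compounds, both of those carrying a fluorinated aromatic ring therefore have higher numbers than compound 2, whether or not an ester is present. Nothing available explains this rise. On these data alone, whether a simple hydroxyl or an amine at this carbon would keep the number close to that of compound 2 remains open. So does the separate contribution of the ring's fluorine and hydroxyl.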